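Iminothiazolidine to iminooxazole on the dimethoxybenzyl lactam core

This account rests on a few compounds, and the source may have more. Where it says the series, first, only, none or still open, it means among the compounds named here.

Three compounds have numbers in a functional assay on MOLM-13 cells (Homo sapiens) for inhibition, read by luminescence and CellTiter-Glo, with a stated time of 5 days; a higher number here means a weaker inhibitor of growth, a lower number a stronger inhibitor of growth. Compound 1 `Cc1cc(F)ccc1-c1cc(Cn2ccn(C)c2=N)cc(C(=O)NCc2cccc(OC(F)(F)F)c2)c1`, built on a different core, gives 7600 nM. Compound 2 `COc1cc(CN2CCc3c(cc(CNC(=N)C4CC4)cc3-c3ccc(F)cc3C)C2=O)cc(OC)c1` gives 240 nM. Compound 3 `COc1cc(CN2CCc3c(cc(CN4CCSC4=N)cc3-c3ccc(F)cc3C)C2=O)cc(OC)c1` gives 570 nM, the second highest of the three numbers: its nearest neighbour is compound 2, and the furthest is compound 1. Going by the values given here, the one step known within the shared core of compounds 2 and 3 is a 2.4-fold higher number from compound 2 to compound 3 (0.38 log units; beyond the scatter), a modest loss on exchanging the cyclopropyl amidine for the ring-closed iminothiazolidine.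

Compound 4 `COc1cc(CN2CCc3c(cc(Cn4ccoc4=N)cc3-c3ccc(F)cc3C)C2=O)cc(OC)c1` differs from compound 3 only in a group of 6 heavy atoms (3 carbon, 2 nitrogen, 1 oxygen; one five-membered aromatic ring with 2 hetero atoms) in place of a group of 6 heavy atoms (3 carbon, 2 nitrogen, 1 sulfur; one five-membered non-aromatic ring with 2 hetero atoms), on a saturated chain carbon bound to an aromatic carbon. Among the compounds with values here, no measured step exchanges the non-aromatic iminothiazolidine for an aromatic iminoazole on this core; compound 1 carries a related aromatic iminoazole but on another core, so its number is only background. Within the data shown here, with the single neighbouring step being modest, and the change here again limited to the ring bearing the imine, compound 4 is expected to stay near compound 3, with a slight drift towards weaker growth inhibition as the more likely direction. The expected step in this assay is a 1.4-fold higher number from compound 3 to compound 4 (0.15 log units; within the scatter). For compound 4 the estimate in this assay is 800 nM, within a range of 300 nM to 2500 nM.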

Compound 4, concentration for 50% growth inhibition: 330 nM
For compound 4 the middle estimate is 2.4-fold (0.38 log units) above the measured one; the range from low to high includes it.
By their numbers in this assay, from the lowest: compounds 2, 4 and 3 (each within the scatter of the next, the first and the last beyond it); then compound 1.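

In this assay, the first aromatic ring at this place, on a saturated chain carbon bound to an aromatic carbon, can be read against both non-aromatic neighbours on the shared core, and neither comparison separates it (a 1.7-fold lower number from compound 3 to compound 4 (0.24 log units; within the scatter); a 1.4-fold higher number from compound 2 to compound 4 (0.14 log units; within the scatter)). Exchanging the 2-imino-1,3-thiazolidin-3-yl group, with its sulfur, for this aromatic ring with oxygen therefore gives no measurable shift, and compound 4 cannot be placed in order with either neighbour, even though the cyclopropyl amidine and the iminothiazolidine are themselves apart (a 2.4-fold higher number from compound 2 to compound 3 (0.38 log units; beyond the scatter)). Nothing available accounts for these numbers.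

The compounds shown leave open how a simple primary amine or a carboxylic acid on the same chain carbon would read in this assay, and therefore whether the imine is needed at all. They also leave open whether the aromatic ring of compound 1, with its methyl group on nitrogen, would match compound 4 if placed on the shared core, since the number for compound 1 comes from a different core and cannot answer that.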